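Swapping a Thiophene Sulfonamide for a Methoxyphenyl One

The source may report more compounds than this note shows. Statements on the series, on what has been measured and on what is new or still open speak of the compounds shown alone.

Measured so far in an assay on cells for inhibition of HSP60/HSP10 (Homo sapiens), with a stated time of 60 min; on this read-out higher numbers stand for weaker inhibition and lower numbers for stronger inhibition:
- compound 1, `O=S(=O)(Nc1ccc2oc(-c3ccccc3)nc2c1)c1cccs1`, gives 90000 nM
- compound 2, `O=S(=O)(Nc1ccc(-c2nc3cc(NS(=O)(=O)c4ccccc4F)ccc3o2)cc1)c1ccccc1F`, gives 57000 nM
- compound 3, `O=S(=O)(Nc1ccc(-c2nc3ccccc3o2)cc1)c1cccc(F)c1`, gives 71000 nM

All three compounds share a core carrying a sulfonamide, and all three are weak inhibitors in this assay. Compound 1 has the highest of the three numbers, but its gaps to compound 3 and to compound 2 both lie within the usual scatter of repeated measurements, so none of the three can be set apart from the others.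

Compound 4, `COc1ccccc1S(=O)(=O)Nc1ccc2oc(-c3ccccc3)nc2c1`, has not yet been measured. It differs from compound 1 in one place: 2-methoxyphenyl in place of thiophen-2-yl on a sulfonyl sulfur. For the measured compounds named here, nothing among the measured compounds shows what this particular exchange does, since no pair of them differs in only one spot. The three numbers sit close together despite different groups on the sulfonyl sulfur and on the rest of the scaffold, so the step from compound 1 to compound 4 is expected to stay within the scatter, with perhaps a slight lean toward a lower number, a 1.3-fold lower number from compound 1 to compound 4 (0.11 log units; within the scatter). Compound 4 is therefore estimated at 70000 nM, expected to fall between 30000 nM and 180000 nM in this assay.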

Compound 4, half-maximal inhibitory concentration: > 100000 nM
Compound 4: only a limit was reported; the forecaster's own chance of this, stated with the estimate: 20%; at least 1.4-fold (0.15 log units) between middle value and limit.
By their numbers in this assay, from the lowest: compounds 2, 3 and 1 (each within the scatter of the next). At a limit, above all of these: compound 4.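

In this assay compound 4 gives > 100000 nM, which is a limit and not a number. For the compounds shown here, this is the first comparison here in which only one place changes, and 2-methoxyphenyl in place of thiophen-2-yl on the sulfonyl sulfur gives an at least 1.1-fold higher number from compound 1 to compound 4 (0.04 log units; that floor lies within the scatter), so this exchange brings no lower number, although the floor of the step does not separate the two compounds. Because compound 4 is known only as a limit, the true size of the step cannot be read: the limit of > 100000 nM in this assay, at which 1 of the 4 values shown sits.

Still open, on these data alone, is whether the six-membered aromatic ring or its methoxy group matters more for this result, a question that a plain phenyl group on the sulfonyl sulfur could help to answer. Also open is whether any group at this place can bring the number clearly down in this assay, for example a ring carrying an amine or a carboxylic acid, since the compounds shown offer only this one single-place comparison.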